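Replacing methyl with nitro in compound 1

The source may hold more compounds than are shown below. What is called first, only, known or untested is meant among the compounds shown, and "the series" means these compounds.

Measured in a functional assay on PC-3 cells (Homo sapiens) for inhibition, read by sulforhodamine B assay; on this read-out higher numbers stand for weaker inhibition of growth and lower numbers for stronger inhibition of growth:
- compound 1 `Cc1ccc(CN2CCC=C(CCC(=O)NO)C2=O)cc1`: 8100 nM
- compound 2 `Cc1cccc(CN2CCC=C(CCC(=O)NO)C2=O)c1`: > 10000 nM (a limit)
- compound 3 `Cc1ccccc1CN1CCC=C(CCC(=O)NO)C1=O`: > 10000 nM (a limit)

Compound 1 alone has a true number, and the other two compounds sit at the limit of > 10000 nM in this assay, at which 2 of the 3 values shown sit. Compound 4 `O=C(CCC1=CCCN(Cc2ccc([N+](=O)[O-])cc2)C1=O)NO` differs from compound 1 by nitro in place of methyl on an aromatic carbon, with nitro in place of methyl on an aromatic carbon, para to a large group. The measured steps only move the methyl: an at least 1.2-fold higher number from compound 1 to compound 2 (0.09 log units; that floor lies within the scatter), an at least 1.2-fold higher number from compound 1 to compound 3 (0.09 log units; that floor lies within the scatter) and a step that the two limits leave unreadable from compound 2 to compound 3. None of them replaces the group, and neither floor goes beyond the scatter. No step beyond the scatter is therefore expected in this assay, and the estimate is a 1.0-fold lower number from compound 1 to compound 4 (0.01 log units; within the scatter). For compound 4 the expected value is 8000 nM, with an estimated range from 3500 nM to 16000 nM.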

Compound 4, concentration for 50% growth inhibition: 3010 nM
The estimate for compound 4 lay 2.7-fold (0.42 log units) above the measured number; measured number below the stated range.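

In this assay, nitro in place of methyl gives a 2.7-fold lower number from compound 1 to compound 4 (0.43 log units; beyond the scatter). This shows that the number responds to the group on this aromatic carbon, para to a large group, and not only within the scatter. The earlier compounds, which only moved the methyl, could not show a step of readable size beyond the scatter, because their values stop at a limit: the limit of > 10000 nM in this assay, at which 2 of the 4 values shown sit.

Why nitro gives this step stays open. So does whether an amine or a carboxylic acid at this place would move the number the same way.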